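Extending the methyl of compound 3 to ethyl

This account rests on a few compounds, and the source may have more. Where it says the series, first, only, none or still open, it means among the compounds named here.

Measured in a toxicity assay on microsomes from liver (Homo sapiens) for metabolic stability, read by LC-MS, using NADPH, tested at 1 uM; a higher number here means faster removal of the compound, a lower number slower removal:
compound 1 `CCOc1ncc(-c2nc(C(F)(F)F)sc2N2CCN(C(=O)Cn3nc(C)nc3C)[C@H](C)C2)cn1`: < 10 mL.min-1.g-1 (a limit)
compound 2 `Cc1nc(C)n(CC(=O)N2CCN(c3sc(C(F)(F)F)nc3-c3cnc(OC4CCC4)nc3)C[C@H]2C)n1`: 51 mL.min-1.g-1
compound 3 `Cc1ncc(-c2nc(C(F)(F)F)sc2N2CCN(C(=O)Cn3nc(C)nc3C)[C@H](C)C2)cn1`: < 10 mL.min-1.g-1 (a limit)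

In this assay compound 3 stands at < 10 mL.min-1.g-1, which is a limit and not a number. The low end of the series is crowded: the limit of < 10 mL.min-1.g-1 in this assay, at which 2 of the 3 values shown sit.

Compound 4 `CCc1ncc(-c2nc(C(F)(F)F)sc2N2CCN(C(=O)Cn3nc(C)nc3C)[C@H](C)C2)cn1` differs from compound 3 by methyl in place of hydrogen on a saturated chain carbon bound to an aromatic carbon, turning methyl to ethyl.

Among the compounds with values here, three measured steps bear on this, all changing the group at the same place. Cyclobutyl in place of ethyl on an oxygen gives an at least 5.1-fold higher number from compound 1 to compound 2 (0.70 log units; beyond the scatter). Methyl in place of cyclobutyloxy gives an at least 5.1-fold lower number from compound 2 to compound 3 (0.70 log units; beyond the scatter). Methyl in place of ethoxy gives a step that the two limits leave unreadable from compound 1 to compound 3.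

The large values appear only with the cyclobutyloxy group of compound 2. The expectation for ethyl rests on compound 1, whose ethoxy group gives < 10 mL.min-1.g-1, again a limit. A small upward move at most is therefore expected, possibly with a result that is again only a limit. The expected step is an at least 1.1-fold higher number from compound 3 to compound 4 (0.04 log units; that floor lies within the scatter). For compound 4 the estimated value is 11 mL.min-1.g-1, with an expected range from 5 mL.min-1.g-1 to 28 mL.min-1.g-1.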

Compound 4, intrinsic clearance in microsomes: 43 mL.min-1.g-1
Compound 4: middle estimate off by 3.9-fold (0.59 log units), on the low side; measured number above the stated range.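

In this assay a methyl in place of hydrogen on a saturated chain carbon bound to an aromatic carbon gives an at least 4.3-fold higher number from compound 3 to compound 4 (0.63 log units; beyond the scatter) and so lifts the compound off the low end of the series, which shows that high values at this place do not require the cyclobutyloxy group. Ethyl in place of cyclobutyloxy gives a 1.2-fold lower number from compound 2 to compound 4 (0.07 log units; within the scatter) and leaves the two compounds indistinguishable, whereas ethyl in place of ethoxy gives an at least 4.3-fold higher number from compound 1 to compound 4 (0.63 log units; beyond the scatter) and so shows that the ethoxy group is a poor guide to ethyl at this place. The steps from compound 1 and compound 3 give only floors, and their full size cannot be read because both compounds sit at a limit: the limit of < 10 mL.min-1.g-1 in this assay, at which 2 of the 4 values shown sit.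

Going by these compounds, whether a longer chain such as propyl, or a branched one such as isopropyl, stays level with ethyl or moves further in this assay remains open. Also open, on these data alone, is whether an amine or a cyclopropyl group on the same aromatic carbon would sit with methyl or with ethyl.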